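Dichloro to difluoro swap, single-concentration cytotoxicity notes

The source may report more compounds than this note shows. Statements on the series, on what has been measured and on what is new or still open speak of the compounds shown alone.

Measured so far:
compound 1 `COc1cc(-c2cc(/C=C/C(=O)c3ccc(Cl)c(Cl)c3)[nH]n2)cc(OC)c1OC` gives 99%
compound 2 `COc1ccc(-c2cc(/C=C/C(=O)c3ccc(N)cc3)[nH]n2)cc1OC` gives 102%

In a functional assay on SK-MEL-2 cells (Homo sapiens) for cytotoxicity, read by sulforhodamine B assay, with a stated time of 48 h, tested at 1 uM (on this read-out lower numbers stand for a stronger effect and higher numbers for a weaker effect at the one concentration tested), compound 1 and compound 2 give numbers that lie within the scatter of each other, and both point to essentially no effect at the concentration tested. Compound 3 `COc1cc(-c2cc(/C=C/C(=O)c3ccc(F)c(F)c3)[nH]n2)cc(OC)c1OC` differs from compound 1 by 3,4-difluorophenyl in place of 3,4-dichlorophenyl on a carbonyl carbon. Among the measured compounds shown here, no step between measured compounds is available for comparison. Since compound 1 already sits near no effect with 99%, the exchange is expected to move the read-out by no more than the scatter in this assay. Compound 3 is therefore estimated at 100%, within 88% to 110%, an expected step of a number 1 percentage points higher from compound 1 to compound 3 (within the scatter) within the scatter.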

Compound 3, a percentage reported as activity, at one concentration (the size of the read-out at that concentration, not a potency): 94%
Compound 3: the middle estimate sits 6 percentage points above what was measured, and the stated range covers the measured number.
By their numbers in this assay, from the lowest: compounds 3, 1 and 2 (each within the scatter of the next).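

With 3,4-difluorophenyl in place of 3,4-dichlorophenyl on a carbonyl carbon, this assay gives a number 5 percentage points lower from compound 1 to compound 3 (within the scatter). Among the compounds shown here, this is the first matched exchange at this position: the two halogen pairs cannot be told apart here, and both compounds stay close to no effect at the single concentration tested. Nothing available bears on the reason for this result. Open, from the compounds shown here alone, is whether a carboxylic acid or a nitrile in place of the halogens would give a read-out beyond the scatter, and whether the series shows any effect at other concentrations.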